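Trifluoromethyl for methyl on a nitro-bearing coumarin amide

The compounds below may be only part of what the source reports. "The series", "measured", "known", "first", "only" and "open" are said of these compounds alone.

Measured compounds:
compound 1 `O=C(Nc1cccc(C(F)(F)F)c1)c1cc2ccccc2oc1=O` 3300 nM
compound 2 `Cc1cccc(NC(=O)c2cc3cc([N+](=O)[O-])ccc3oc2=O)c1` 39100 nM

In an assay for inhibition of Amine oxidase [flavin-containing] B (Homo sapiens), read by fluorescence, using microsomes, with a stated time of 15 min (on this read-out lower numbers stand for stronger inhibition and higher numbers for weaker inhibition), compound 2 gives 39100 nM, the highest number of the two measured compounds. Its nearest neighbour, compound 1, gives 3300 nM in this assay, a much lower number and beyond the usual scatter; compounds 1 and 2 differ in more than one place, so what this gap reflects cannot be split between the two changes.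

Compound 3 `O=C(Nc1cccc(C(F)(F)F)c1)c1cc2cc([N+](=O)[O-])ccc2oc1=O` has not yet been measured. It differs from compound 2 in one place: trifluoromethyl in place of methyl on an aromatic carbon. Compound 3 thus carries the trifluoromethyl of compound 1 together with the nitro group of compound 2.

Among the measured compounds shown here, since no single-change step between measured compounds is available, the expectation rests on the two values alone. Compound 3 is expected to move toward the lower number of compound 1, though only part of the way, since the nitro group of compound 2 remains. The step from compound 2 to compound 3 is therefore estimated as a 3.3-fold lower number from compound 2 to compound 3 (0.51 log units; beyond the scatter). For compound 3 the estimated value in this assay is 12000 nM, with a range from 4000 nM to 40000 nM.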

Compound 3, half-maximal inhibitory concentration: 22800 nM
Estimate against measurement, compound 3: 1.9-fold (0.28 log units) below; the range from low to high includes it.
By their numbers in this assay, from the lowest: compound 1; then compounds 3 and 2 (each within the scatter of the next).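

In this assay the step of trifluoromethyl in place of methyl on an aromatic carbon, meta to a large group, is a 1.7-fold lower number from compound 2 to compound 3 (0.23 log units; within the scatter) and so, on the nitro-bearing core, this change at this position does not separate the two compounds. Among the compounds shown here, the other single change, nitro in place of hydrogen on an aromatic carbon with the trifluoromethyl kept, is a 6.9-fold higher number from compound 1 to compound 3 (0.84 log units; beyond the scatter) and gives the first reading of the nitro group alone, which the earlier pair could not provide. Of the two changes that separate compound 1 from compound 2, only the nitro step lies beyond the scatter, and that holds for the trifluoromethyl-bearing compounds, the only setting in which the nitro step can be read.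

Left open is whether the exchange of methyl and trifluoromethyl would read the same on the core without the nitro group, and whether an amine or a carboxylic acid in the place of the nitro group would stay near compound 1 or near compound 3. Nothing at hand bears on why either step has the size it has.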